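Replacing a Propyl Chain with a Phenyl Ring

The source may hold more compounds than are shown below. What is called first, only, known or untested is meant among the compounds shown, and "the series" means these compounds.

Three compounds share a core and differ only in one group on it. Compound 1 `O=C(Nc1cc(C(F)(F)F)cc(C(F)(F)F)c1)c1cnc(Cl)nc1C(F)(F)C(F)(F)F` gives 800 nM in an assay on Jurkat cells for activation of nuclear factor NF-kappa-B complex (Homo sapiens); on this read-out lower numbers stand for stronger inhibition and higher numbers for weaker inhibition. Compound 2 `O=C(Nc1cc(C(F)(F)F)cc(C(F)(F)F)c1)c1cnc(Cl)nc1-c1cccs1` gives 9800 nM, and compound 3 `CCCc1nc(Cl)ncc1C(=O)Nc1cc(C(F)(F)F)cc(C(F)(F)F)c1` gives 500 nM. Compound 3 stands at the lowest number of the three, though compound 1 sits within the scatter of it; compound 2 lies well apart, as shown by the step of a 20-fold lower number from compound 2 to compound 3 (1.29 log units; beyond the scatter).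

Compound 4 `O=C(Nc1cc(C(F)(F)F)cc(C(F)(F)F)c1)c1cnc(Cl)nc1-c1ccccc1` takes the same core and carries the change (phenyl in place of propyl on an aromatic carbon). Two earlier steps bear on this. For the measured compounds named here, the step of a 12-fold higher number from compound 1 to compound 2 (1.09 log units; beyond the scatter) and the step of a 20-fold lower number from compound 2 to compound 3 (1.29 log units; beyond the scatter) both show that the one compound bearing an aromatic ring at this position gives a far higher number than either chain, while the two chains sit close together, as the step of a 1.6-fold lower number from compound 1 to compound 3 (0.20 log units; within the scatter) shows. A phenyl ring is also an aromatic ring placed at this carbon, so a large rise in number is expected. For compound 4 the estimate is 6000 nM, within a range from 1500 nM to 25000 nM, an expected step of a 12-fold higher number from compound 3 to compound 4 (1.08 log units; beyond the scatter).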

Compound 4, half-maximal inhibitory concentration: 400 nM
Estimate against measurement, compound 4: 15-fold (1.18 log units) above; the whole stated range lies above it.
By their numbers in this assay, from the lowest: compounds 4, 3 and 1 (each within the scatter of the next); then compound 2.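

At this position an aromatic ring does not by itself bring a high number: in this assay the step of a 1.3-fold lower number from compound 3 to compound 4 (0.10 log units; within the scatter) leaves phenyl and propyl level, and the step of a 2.0-fold lower number from compound 1 to compound 4 (0.30 log units; within the scatter) leaves phenyl level with 1,1,2,2,2-pentafluoroethyl. Among these groups thiophen-2-yl alone stands apart, with the step of a 25-fold lower number from compound 2 to compound 4 (1.39 log units; beyond the scatter) showing that the earlier link between a ring here and a high number rested on compound 2 only. No measurement at hand accounts for the gap between thiophen-2-yl and phenyl.

Still open, on these data alone, is whether compound 2 is a lone case or whether another five-membered ring, such as furan-2-yl, behaves the same way. Also open, as far as these compounds go, is how a phenyl ring carrying a methoxy group, a longer chain such as hexyl, or a carboxylic acid would fare on this carbon.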